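Chloro for dimethylamino on the core: expected inhibition

The compounds below may be only part of what the source reports. "The series", "measured", "known", "first", "only" and "open" are said of these compounds alone.

In a functional assay on EL4 cells (Mus musculus) for inhibition, tested at 100 uM (on this read-out lower numbers stand for less inhibition and higher numbers for more inhibition at the one concentration tested (going by the name of the read-out)), compound 1 `CN(C)c1nccc2c1ncn2[C@H]1C[C@H](O)[C@@H](CO)O1` gives only a limit of the assay, < 5%. Compound 2 `CNc1[nH]ccc2ncnc1-2` likewise returns a limit, < 5%. Compound 3 `OC[C@H]1O[C@@H](n2cnc3cnccc32)[C@H](O)[C@@H]1O` is a limit in both of its entries, < 5%; < 5% (2 entries). Among the compounds with values here, no two measured compounds differ in a single place, so no measured step exists; the values gather at the limit of < 5% in this assay, at which 2 of the 3 values shown sit, and compound 1 cannot be set apart from the others on these numbers. Compound 4 `OC[C@H]1O[C@@H](n2cnc3c(Cl)nccc32)C[C@@H]1O` is compound 1 with chloro in place of dimethylamino on an aromatic carbon. With every value a limit there is no measured basis for a step in either direction, and the expected step of a number no lower from compound 1 to compound 4 (the limit leaves the size open) is none beyond the scatter. Compound 4 is therefore estimated at 5%, with a range from 0% to 20%, most probably reported again only as a limit.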

Compound 4, a percentage reported as inhibition, at one concentration (the size of the read-out at that concentration, not a potency): < 5%
Compound 4: no number, only a limit; the forecaster's own chance of this, stated with the estimate: 65%; the middle value lies on the limit itself.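

The step between compound 1 and compound 4 cannot be read, as both are only limits in this assay: the limit of < 5% in this assay, at which 3 of the 4 values shown sit.

The compounds shown leave open how chloro and dimethylamino compare on the shared core, since none of them gives a number for inhibition.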